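Chloropyrazole replaces aminomethyl pyrazole on a piperazine amide

The source may hold more compounds than are shown below. What is called first, only, known or untested is meant among the compounds shown, and "the series" means these compounds.

Measured compounds:
compound 1, `Cc1nn(CC(=O)N2CCN(c3sc(C(F)(F)F)nc3-c3nc4ccccc4[nH]3)C[C@H]2C)cc1CN(C)C`: 2.7 nM
compound 2, `C[C@@H]1CN(c2sc(C(F)(F)F)nc2-c2nc3cc(Cl)ccc3[nH]2)CCN1C(=O)Cn1cnc2cccnc21`: 2.8 nM

In a functional assay on CHO-K1 cells for antagonist activity at C-X-C chemokine receptor type 3 (Homo sapiens), read by FLIPR, with a stated time of 10 min, in the presence of a further agent that is not named here (on this read-out lower numbers stand for stronger inhibition and higher numbers for weaker inhibition), compound 1 gives 2.7 nM and compound 2 gives 2.8 nM. Compound 1 holds the smaller of the two numbers, but its gap to compound 2 lies within the scatter, so the two are not told apart in this assay. Compound 3, `C[C@@H]1CN(c2sc(C(F)(F)F)nc2-c2nc3ccccc3[nH]2)CCN1C(=O)Cn1cc(Cl)cn1`, has not been measured there. It differs from compound 1 by 4-chloro-1H-pyrazol-1-yl in place of 4-((dimethylamino)methyl)-3-methyl-1H-pyrazol-1-yl on a saturated chain carbon bound to a carbonyl carbon. Among the measured compounds shown here, no measured pair shows this change, so its size is open. Since a group that sits on the same chain carbon is simply exchanged for a smaller one, a modest loss is expected, probably near the edge of the scatter, and the expected step is a 2.2-fold higher number from compound 1 to compound 3 (0.35 log units; beyond the scatter). Compound 3 is therefore estimated at 6 nM in this assay, with a range from 2 nM to 20 nM.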

Compound 3, half-maximal inhibitory concentration: 1.7 nM
Estimate against measurement, compound 3: 3.5-fold (0.55 log units) above; measured number outside the range, below it.
By their numbers in this assay, from the lowest: compounds 3, 1 and 2 (each within the scatter of the next).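

At the saturated chain carbon bound to a carbonyl carbon, 4-chloro-1H-pyrazol-1-yl in place of 4-((dimethylamino)methyl)-3-methyl-1H-pyrazol-1-yl gives a 1.6-fold lower number from compound 1 to compound 3 (0.20 log units; within the scatter) in this assay, so the two compounds are not told apart there. In this pair, the entering group has fewer heavy atoms and hydrogen-bond acceptors and no dimethylamino group, yet the number stays within the scatter. Nothing at hand gives a reason for this result.

Open, on these data alone, is whether the chlorine matters: a pyrazol-1-yl carrying a hydrogen, a nitrile or a carboxylic acid in its place would show that in this assay. Also open, as far as these compounds go, is what the dimethylamino group and the methyl each contribute, as this single step exchanges them together.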